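Cycloheptyl to phenyl on the amine-bound carbon

The source may report more compounds than this note shows. Statements on the series, on what has been measured and on what is new or still open speak of the compounds shown alone.

Measured so far in a functional assay on the whole organism for antagonist activity, with Mus musculus as the target; on this read-out lower numbers stand for an effect already at smaller amounts and higher numbers for an effect only at larger amounts of compound:
compound 1 `COc1cc(N)c(Cl)cc1NC(=O)C1CCN(Cc2cccc(C)c2)CC1` gives 2.4 mg/kg
compound 2 `COc1cc(N)c(Cl)cc1NC(=O)C1CCN(Cc2cccc(C#N)c2)CC1` gives > 4 mg/kg, which is a limit of this assay
compound 3 `COc1cc(N)c(Cl)cc1NC(=O)C1CCN(CC2CCCCCC2)CC1` gives > 10 mg/kg, which is a limit of this assay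

Compound 3 thus stands only at a limit, not at a number. Compound 4 `COc1cc(N)c(Cl)cc1NC(=O)C1CCN(Cc2ccccc2)CC1` differs from it by phenyl in place of cycloheptyl on a saturated chain carbon bound to an amine nitrogen in a ring. The measured step that bears on this place is an at least 4.1-fold higher number from compound 1 to compound 3 (0.61 log units; beyond the scatter), which ran from 3-methylphenyl to cycloheptyl; the move to compound 4 runs back to an aromatic ring, now without the methyl. On that aromatic ring, an at least 1.6-fold higher number from compound 1 to compound 2 (0.22 log units; that floor lies within the scatter) was of unreadable size. Compound 4 is therefore expected to need a lower dose than compound 3, with an estimated step of an at least 3.3-fold lower number from compound 3 to compound 4 (0.52 log units; beyond the scatter). For compound 4 the estimated value is 3 mg/kg, between 1.5 mg/kg and 8 mg/kg.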

Compound 4, dose for half-maximal effect: 0.5 mg/kg
The estimate for compound 4 lay 6.0-fold (0.78 log units) above the measured number; measured number below the stated range.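

On this carbon, the aromatic ring of compound 4 does far better than the saturated ring in this assay, with an at least 20-fold lower number from compound 3 to compound 4 (1.30 log units; beyond the scatter). The ring also works best bare among those shown: hydrogen in place of methyl gives a 4.8-fold lower number from compound 1 to compound 4 (0.68 log units; beyond the scatter), and hydrogen in place of cyano gives an at least 8.0-fold lower number from compound 2 to compound 4 (0.90 log units; beyond the scatter). Compound 2 and compound 3 each stand only at a limit of the assay, so their steps are floors.

Still open, on these data alone, is whether fluoro or hydroxy on the aromatic ring would match hydrogen, and whether cyclohexyl would fall short like cycloheptyl.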